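The source may report more compounds than this note shows. Statements on the series, on what has been measured and on what is new or still open speak of the compounds shown alone.

The three measured compounds share one core and differ only in the group on the amide-type nitrogen. Compound 1 `COc1cc2c(cc1OC)C(CC(=O)Nc1ccc(Br)cc1)CC2` gives 37.5% in a functional assay on the whole organism (strain Swiss Albino) for inhibition, with Mus musculus as the target, in the writhing test, with a stated time of 1 h, at a dose of 100 mg/kg by the oral route; a higher number here means more inhibition at the dose given (going by the name of the read-out), a lower number less inhibition. Compound 2 `COc1cc2c(cc1OC)C(CC(=O)Nc1cccc(C)c1)CC2` gives 54.3% in this assay, and compound 3 `COc1cc2c(cc1OC)C(CC(=O)Nc1ccc([N+](=O)[O-])cc1)CC2` gives 55.8%. The step of a number 16.8 percentage points higher from compound 1 to compound 2 (beyond the scatter) and the step of a number 18.3 percentage points higher from compound 1 to compound 3 (beyond the scatter) are both beyond the scatter. Compound 2 stands second highest of the three numbers; its value and that of compound 3 lie within the scatter of each other, while compound 1 sits beyond the scatter below it.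

Compound 4 `COc1cc2c(cc1OC)C(CC(=O)Nc1ccncc1)CC2` is not yet measured. Its difference from compound 2 is pyridin-4-yl in place of 3-methylphenyl on an amide-type nitrogen. For the measured compounds named here, neither measured step bears directly on this change: the step from compound 1 to compound 2 exchanges one six-membered aromatic ring of carbon only for another, and the step from compound 1 to compound 3 changes a substituent on such a ring; no measured pair replaces a ring of carbon only with a ring carrying a hetero atom. The two measured steps show that changing the group on the amide-type nitrogen can move the read-out by a modest amount, so a modest step in either direction in this assay cannot be ruled out. Going by the values given here, with no bearing step, the step of a number 2.3 percentage points lower from compound 2 to compound 4 (within the scatter) is expected to lie within the scatter. Compound 4 is therefore estimated at 52%, within 35% to 68%.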

Compound 4, a percentage reported as inhibition, in the whole organism at one dose (the size of the read-out at that dose, not a potency): 60.1%
Compound 4: the middle estimate sits 8.1 percentage points below what was measured; low and high end bracket the measured number.
By their numbers in this assay, from the lowest: compound 1; then compounds 2, 3 and 4 (each within the scatter of the next).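

For the compounds shown here, with pyridin-4-yl on the amide-type nitrogen, the series now includes an aromatic ring carrying a hetero atom, whereas the earlier compounds held only rings of carbon. In this assay the step of a number 5.8 percentage points higher from compound 2 to compound 4 (within the scatter) shows that this position accepts the exchange of 3-methylphenyl for pyridin-4-yl, including the added hydrogen-bond acceptor counted for the new ring, with no change that can be told from scatter. The step of a number 22.6 percentage points higher from compound 1 to compound 4 (beyond the scatter) adds a third group that stands clear of the 4-bromophenyl of compound 1, which leaves compound 1 apart from all the others in the series; nothing shown here offers any measured explanation of these numbers.

As far as these compounds go, it remains open whether the position needs an aromatic ring at all, a question that a piperidin-4-yl ring or a plain butyl chain on the same nitrogen would address. From the compounds shown here alone, it is equally open whether the place of the ring nitrogen matters, which pyridin-3-yl and pyridin-2-yl would test, and how a pyrimidine ring or a pyridine ring bearing an amine would read in this assay.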